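Pentyl in Place of Tert-Butyl: What Compound 4 May Show

The source may report more compounds than this note shows. Statements on the series, on what has been measured and on what is new or still open speak of the compounds shown alone.

Compound 1, `Fc1ccc(-c2nnc3nnc(N4CCCC4)n3n2)cc1`, gives 4560 nM in a functional assay on HL-60 cells (Homo sapiens) for cytotoxicity, read by MTT assay, with a stated time of 72 h; on this read-out lower numbers stand for stronger inhibition and higher numbers for weaker inhibition.
Compound 2, `CC(C)(C)c1nnc2nnc(N3CCCC3)nn12`, gives > 100000 nM in this assay, which is a limit of the assay and not a number.
Compound 3, `c1ccc(-c2nnc3nnc(N4CCCC4)n3n2)cc1`, gives > 100000 nM in this assay, again a limit rather than a number.

Compound 2 therefore stands at the edge of what this assay can report: its value is the limit of > 100000 nM in this assay, at which 2 of the 3 values shown sit. Among the three measured compounds only compound 1 returns a number, and it carries a fluoro-substituted aromatic ring rather than an alkyl group. Going by the values given here, the single measured step, an at least 21-fold higher number from compound 1 to compound 3 (1.34 log units; beyond the scatter), concerns that aromatic substituent and does not touch the alkyl position borne by compound 2, so it offers no direct guide to the change considered here.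

Compound 4, `CCCCCc1nnc2nnc(N3CCCC3)nn12`, differs from compound 2 by pentyl in place of tert-butyl on an aromatic carbon. Among the compounds with values here, no measured step bears on an alkyl-for-alkyl exchange at this position, and both alkyl-free comparators other than compound 1 sit at the limit. Compound 4 is therefore expected to remain at or near the limit, so that the estimated step that the limit leaves unreadable from compound 2 to compound 4 is not expected to carry it clearly beyond the scatter. For compound 4 the estimate is 120000 nM, with a range from 30000 nM to 400000 nM.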

Compound 4, half-maximal inhibitory concentration: 42500 nM
Compound 4: middle estimate off by 2.8-fold (0.45 log units), on the high side; the measured number falls inside the stated range.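

Going by these compounds alone, until now, no step had touched the alkyl group on this aromatic carbon, between two ring nitrogen atoms. In this assay, pentyl in place of tert-butyl gives an at least 2.3-fold lower number from compound 2 to compound 4 (0.37 log units; beyond the scatter), which shows that this position can shift the read-out beyond the scatter, and that a number can be reached here with an alkyl group and no aromatic substituent at all. Compound 2 gives > 100000 nM, which is a limit of the assay and not a number, so the true size of this step stays unknown and the printed size is only its lower bound, set by the end of the scale: the limit of > 100000 nM in this assay, at which 2 of the 4 values shown sit.

From the compounds shown here alone, whether a shorter chain such as butyl or a longer chain such as heptyl would push the number further down at this place remains open, as does the outcome for a pentyl chain ending in an amine or a carboxylic acid. This single pair also cannot separate the effect of the added carbon from that of replacing a branched group with a straight chain.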